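The source may report more compounds than this note shows. Statements on the series, on what has been measured and on what is new or still open speak of the compounds shown alone.

Of the compounds shown here, three that share one core have been read in an ADME assay on HepG2 2.2.15 cells (Homo sapiens) for cytotoxicity; on this read-out higher numbers stand for lower toxicity in this test and lower numbers for higher toxicity in this test. Compound 1 `CCCC(=O)OCCc1c(-c2ccccc2Cl)c2cc(Cl)ccc2[nH]c1=O` gives 52000 nM, compound 2 `N#CCC(=O)OCCc1c(-c2ccccc2Cl)c2cc(Cl)ccc2[nH]c1=O` gives 100000 nM, and compound 3 `CC(=O)NCC(=O)OCCc1c(-c2ccccc2Cl)c2cc(Cl)ccc2[nH]c1=O` gives 110000 nM. The number for compound 3 is the highest of the three, but only one gap separates it from another: the nearest comparison is a 1.1-fold higher number from compound 2 to compound 3 (0.04 log units; within the scatter), and the furthest is a 2.1-fold higher number from compound 1 to compound 3 (0.33 log units; beyond the scatter).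

Compound 4 `O=C(OCCc1c(-c2ccccc2Cl)c2cc(Cl)ccc2[nH]c1=O)c1ccccc1` carries phenyl in place of acetamidomethyl on a carbonyl carbon, (phenyl in place of acetamidomethyl on a carbonyl carbon). Cut one bond further out, the same difference reads (acetamidomethyl)carbonyl to benzoyl.

Among the measured compounds shown here, no measured step makes this exact exchange, so the evidence is indirect. The other measured change, a 1.9-fold higher number from compound 1 to compound 2 (0.28 log units; within the scatter), stays within the scatter, and the two steps that bear on the question are both small. The entering phenyl is carbon only, as is the ethyl of compound 1, so compound 1 at 52000 nM serves as the closer guide, and the size of a 2.1-fold higher number from compound 1 to compound 3 (0.33 log units; beyond the scatter) suggests a modest move toward a lower number. The expected step is a 2.2-fold lower number from compound 3 to compound 4 (0.34 log units; beyond the scatter). For compound 4 the estimated value is 50000 nM, with an expected range of 20000 nM to 110000 nM.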

Compound 4, half-maximal cytotoxic concentration: 43000 nM
Compound 4: the middle estimate sits 1.2-fold (0.07 log units) above what was measured, and the stated range covers the measured number.
By their numbers in this assay, from the lowest: compounds 4, 1, 2 and 3 (each within the scatter of the next, the first and the last beyond it).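

In this assay, among the compounds shown here, a ring on the carbonyl carbon appears for the first time, and replacing acetamidomethyl with phenyl gives a 2.6-fold lower number from compound 3 to compound 4 (0.41 log units; beyond the scatter) while replacing cyanomethyl with phenyl gives a 2.3-fold lower number from compound 2 to compound 4 (0.37 log units; beyond the scatter) and so both exchanges lie beyond the scatter. Replacing propyl with phenyl gives a 1.2-fold lower number from compound 1 to compound 4 (0.08 log units; within the scatter) and so this position does not separate the aromatic ring from the open carbon chain on this read-out, even though the two groups differ in shape and in ring count. The four compounds therefore loosely place the two groups made of carbon only at the low end and the two groups containing nitrogen at the high end, but compound 1 goes against a clean split, since a 1.9-fold higher number from compound 1 to compound 2 (0.28 log units; within the scatter) stays within the scatter.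

From the compounds shown here alone, whether an amine, a carboxylic acid, a longer chain or a chlorine-bearing benzoyl group on the same carbonyl carbon would follow this loose division remains open. Nothing available here accounts for the differences among these four compounds.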